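From 3-Hydroxyphenyl to 3,5-Dihydroxyphenyl

The source may hold more compounds than are shown below. What is called first, only, known or untested is meant among the compounds shown, and "the series" means these compounds.

Three compounds sharing one core were compared in a functional assay on A549 cells (Homo sapiens) for cytotoxicity (on this read-out higher numbers stand for weaker inhibition and lower numbers for stronger inhibition), and differ only in the substituted phenyl group. Compound 1 (`C=C/C=C\[C@H](C)[C@H](OC(N)=O)[C@@H](C)[C@H](O)[C@@H](C)C/C(C)=C\[C@H](C)[C@@H](O)[C@@H](C)/C=C\CCc1ccc(C)c(F)c1`) gives 4000 nM there, compound 2 (`C=C/C=C\[C@H](C)[C@H](OC(N)=O)[C@@H](C)[C@H](O)[C@@H](C)C/C(C)=C\[C@H](C)[C@@H](O)[C@@H](C)/C=C\CCc1cccc(Cl)c1`) gives 580 nM there, and compound 3 (`C=C/C=C\[C@H](C)[C@H](OC(N)=O)[C@@H](C)[C@H](O)[C@@H](C)C/C(C)=C\[C@H](C)[C@@H](O)[C@@H](C)/C=C\CCc1cccc(O)c1`) gives 190 nM as the lowest of the three numbers. The next structure, compound 4 (`C=C/C=C\[C@H](C)[C@H](OC(N)=O)[C@@H](C)[C@H](O)[C@@H](C)C/C(C)=C\[C@H](C)[C@@H](O)[C@@H](C)/C=C\CCc1cc(O)cc(O)c1`), differs from compound 3 by hydroxy in place of hydrogen on an aromatic carbon with hydroxy in place of hydrogen on an aromatic carbon, which turns 3-hydroxyphenyl into 3,5-dihydroxyphenyl.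

The available evidence is indirect. Hydroxy in place of chloro gave a 3.1-fold lower number from compound 2 to compound 3 (0.48 log units; beyond the scatter) and 3-hydroxyphenyl in place of 3-fluoro-4-methylphenyl gave a 21-fold lower number from compound 1 to compound 3 (1.32 log units; beyond the scatter) while 3-chlorophenyl in place of that same group gave a 6.9-fold lower number from compound 1 to compound 2 (0.84 log units; beyond the scatter) in the same direction. None of these steps adds a second hydroxy, so no shift beyond the scatter is expected in this assay and the estimated change is a 1.2-fold higher number from compound 3 to compound 4 (0.06 log units; within the scatter) with either direction left open. Compound 4 is estimated at 220 nM with an expected range from 70 nM to 700 nM for repeated measurements.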

Compound 4, half-maximal inhibitory concentration: 310 nM
The estimate for compound 4 lay 1.4-fold (0.15 log units) below the measured number, and the stated range covers the measured number.
By their numbers in this assay, from the lowest: compounds 3, 4 and 2 (each within the scatter of the next, the first and the last beyond it); then compound 1.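

In this assay the added hydroxy, meta to a hydroxy group and meta to a large group, gives a 1.6-fold higher number from compound 3 to compound 4 (0.21 log units; within the scatter) and so leaves the number within the scatter: this ring position accepts a second hydroxy without a measurable shift. The 3,5-dihydroxyphenyl group also gives a 1.9-fold lower number from compound 2 to compound 4 (0.27 log units; within the scatter) within the scatter, while a 13-fold lower number from compound 1 to compound 4 (1.11 log units; beyond the scatter) shows that it keeps the full distance from the 3-fluoro-4-methylphenyl group beyond the scatter. No measurement shown here accounts for these numbers.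

The compounds shown leave open whether methoxy in place of either hydroxy would keep the number within the scatter of compound 3. They also leave open how an amine or a carboxylic acid on this same aromatic carbon would read out.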